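Replacing a Methylphenyl Group on Two Related Hydrazide Cores

A few compounds are considered here, and "the series" means these few. Any claim that something is new, unique, unknown or untested is made for them only; others in the source may bear on it.

Measured compounds:
Compound 1 `Cc1ccc(C(=O)NNC(=O)c2ccc(NS(=O)(=O)c3cnc(O)nc3O)cc2)cc1`: > 20000 nM
Compound 2 `O=C(NNC(=O)c1ccccc1Cl)c1ccc(NS(=O)(=O)c2cnc(O)nc2O)cc1`: 3240 nM
Compound 3 `Cc1ccc(C(=O)NNC(=O)c2cccc(NS(=O)(=O)c3cnc(O)nc3O)c2)cc1`: 10100 nM

In a functional assay on SGC-7901 cells (Homo sapiens) for antiproliferative activity, read by MTT assay, with a stated time of 24 h (a higher number here means a weaker inhibitor, a lower number a stronger inhibitor), the value for compound 1 is a limit of the assay rather than a number. Compound 2 differs from compound 1 by 2-chlorophenyl in place of 4-methylphenyl on a carbonyl carbon, and this change gave an at least 6.1-fold lower number from compound 1 to compound 2 (0.79 log units; beyond the scatter); its size is known only as a lower bound because of the limit of > 20000 nM in this assay, at which 1 of the 3 values shown sits. Compound 3 shares its atoms with compound 1 but joins them differently; the difference between the two cores is not broken down here. Compound 4 `O=C(NNC(=O)c1ccccc1Cl)c1cccc(NS(=O)(=O)c2cnc(O)nc2O)c1` is not yet measured and differs from compound 3 by 2-chlorophenyl in place of 4-methylphenyl on a carbonyl carbon, the same kind of change as that from compound 1 to compound 2, made on the other core. Since the earlier step was at least modest, a step of similar direction is expected here, so that compound 4 is estimated to show a 3.4-fold lower number from compound 3 to compound 4 (0.53 log units; beyond the scatter) relative to compound 3. Compound 4 is therefore expected to give about 3000 nM in this assay, most likely between 800 nM and 10000 nM.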

Compound 4, half-maximal inhibitory concentration: 6070 nM
Estimate against measurement, compound 4: 2.0-fold (0.31 log units) below; the range from low to high includes it.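

In this assay, the swap of 4-methylphenyl for 2-chlorophenyl on the second core reads as a 1.7-fold lower number from compound 3 to compound 4 (0.22 log units; within the scatter), so on this core the change does not separate the two compounds from ordinary repeat variation. The change therefore did not carry over from one core to the other at the same size, even though both steps point the same way: the same change on two cores in this assay, an at least 6.1-fold lower number (0.79 log units; beyond the scatter) from compound 1 to compound 2 and a 1.7-fold lower number (0.22 log units; within the scatter) from compound 3 to compound 4, at least 3.7-fold (0.56 log units) apart, beyond the scatter of two such steps Compound 1 carries a limit of the assay and not a number, so the first step has no known upper size, and the comparison does not show why the two cores respond differently: the limit of > 20000 nM in this assay, at which 1 of the 4 values shown sits.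

Only two cores and one swap are shown, so it remains open whether the gap between the cores would appear with any other change. Each step also replaces one group with the other in a single move, and a plain phenyl group or a longer alkyl chain on the same carbonyl carbon would be needed to show how each core responds to other groups.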